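The compounds below may be only part of what the source reports. "The series", "measured", "known", "first", "only" and "open" are said of these compounds alone.

Measured in a functional assay on the whole organism with Cavia porcellus as the target; a higher number here means that more compound is needed for the effect, a lower number that less compound is needed:
- compound 1 `COc1cc(C(=O)NS(=O)(=O)c2ccccc2C)ccc1Cc1cn(C)c2ccc(C(=O)NCC(C)C)cc12`: > 30 umol/kg (a limit of the assay, not a number)
- compound 2 `CCC(C)CNC(=O)c1ccc2c(c1)c(Cc1ccc(C(=O)NS(=O)(=O)c3ccccc3C)cc1OC)cn2C`: 20 umol/kg

For the measured compounds named here, compound 2, at 20 umol/kg, holds the only true number so far. Compound 3 `COc1cc(C(=O)NS(=O)(=O)c2ccccc2C)ccc1Cc1cn(C)c2ccc(NC(=O)CC3CCCC3)cc12` swaps one group on an aromatic carbon, with ((cyclopentylmethyl)carbonyl)amino in place of (2-methylbutyl)carbamoyl on an aromatic carbon. Going by the values given here, the only measured guide is an at least 1.5-fold lower number from compound 1 to compound 2 (0.17 log units; that floor lies within the scatter). That step concerns a single methyl on the chain that now leaves, and its floor stays within the scatter, so it offers only a faint pointer. In this assay, a modest move to a lower number is therefore expected, a 3.3-fold lower number from compound 2 to compound 3 (0.52 log units; beyond the scatter), with wide uncertainty. For compound 3 the estimated value is 6 umol/kg, with an expected range of 1 umol/kg to 30 umol/kg.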

Compound 3, dose for half-maximal effect: 0.41 umol/kg
Compound 3: middle estimate off by 15-fold (1.17 log units), on the high side, and the stated range ends above it.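

In this assay, this aromatic carbon turns out to be highly sensitive to the group it carries, which the earlier methyl change on the chain could not show: ((cyclopentylmethyl)carbonyl)amino in place of (2-methylbutyl)carbamoyl gives a 49-fold lower number from compound 2 to compound 3 (1.69 log units; beyond the scatter). In place of isobutylcarbamoyl, the same group gives an at least 73-fold lower number from compound 1 to compound 3 (1.86 log units; beyond the scatter). That step starts from a limit of the assay, not a number, held by compound 1: the limit of > 30 umol/kg in this assay, at which 1 of the 3 values shown sits.

The change turns the amide around and adds a ring at once, and the compounds shown cannot separate the two. A turned-around amide ending in an open 2-methylbutyl chain, or a cyclohexyl ring in place of cyclopentyl, would leave this open question narrower.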